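3-chlorophenyl in place of 4-chlorophenyl at the assay limit

The source may hold more compounds than are shown below. What is called first, only, known or untested is meant among the compounds shown, and "the series" means these compounds.

Compound 1 `Clc1cccc(Cn2cc(COc3ccccc3)nn2)c1`: > 100 ug/mL
Compound 2 `Cc1ccc(OCc2cn(Cc3ccc(Cl)cc3)nn2)cc1`: > 100 ug/mL

Both entries are limits of the assay, not numbers. In an ADME assay on A549 cells (Homo sapiens) for inhibition, read by MTT assay, with a stated time of 48 h (on this read-out higher numbers stand for weaker inhibition of growth and lower numbers for stronger inhibition of growth), compound 2 stands at > 100 ug/mL, which is a limit. The same holds for compound 1, whose reading of > 100 ug/mL is also a limit. The whole measured record is therefore (the limit of > 100 ug/mL in this assay, at which 2 of the 2 values shown sit).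

Compound 3 `Cc1ccc(OCc2cn(Cc3cccc(Cl)c3)nn2)cc1` has the same atoms as compound 2, joined differently: 3-chlorophenyl in place of 4-chlorophenyl on a saturated chain carbon bound to an aromatic nitrogen. It carries 3-chlorophenyl in place of 4-chlorophenyl on a saturated chain carbon bound to an aromatic nitrogen. Going by the values given here, no measured step shows what such a change does. The expected step, a step that the limit leaves unreadable from compound 2 to compound 3, is no shift beyond the scatter in this assay, with neither direction favoured. Compound 3 is estimated at 120 ug/mL, with an expected range of 60 ug/mL to 250 ug/mL, and the assay may well report only a limit again.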

Compound 3, concentration for 50% growth inhibition: > 100 ug/mL
Compound 3: a limit, no number (the forecaster's own chance of this, stated with the estimate: 80%); the middle value lies beyond the limit too.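

Compound 3 gives > 100 ug/mL in this assay, which is a limit, so no step from compound 1 or compound 2 to compound 3 can be read: the limit of > 100 ug/mL in this assay, at which 3 of the 3 values shown sit.

The compounds shown leave open whether 3-chlorophenyl and 4-chlorophenyl differ at all in growth inhibition.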